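Cytotoxicity of silyl-protected nucleoside ureas

The source may hold more compounds than are shown below. What is called first, only, known or untested is meant among the compounds shown, and "the series" means these compounds.

The measured compounds, with their half-maximal cytotoxic concentrations:
compound 1, `Cc1cn([C@@H]2O[C@H](CO)[C@@]3(OS(=O)(=O)C=C3NC(=O)NC(=O)c3ccccc3)[C@H]2O)c(=O)n(C)c1=O`, > 50000 nM;
compound 2, `Cc1cn([C@@H]2O[C@H](CO[Si](C)(C)C(C)(C)C)[C@@]3(OS(=O)(=O)C=C3NC(=O)N(C(=O)Nc3ccccc3)c3ccccc3)[C@H]2O[Si](C)(C)C(C)(C)C)c(=O)n(C)c1=O`, 13000 nM;
compound 3, `Cc1cn([C@@H]2O[C@H](CO[Si](C)(C)C(C)(C)C)[C@@]3(OS(=O)(=O)C=C3NC(=O)NCc3ccccc3)[C@H]2O[Si](C)(C)C(C)(C)C)c(=O)n(C)c1=O`, 4100 nM.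

In an ADME assay on HEL cells (Homo sapiens) for cytotoxicity, with a stated time of 3 days (a lower number here means that less compound is tolerated, a higher number that more compound is tolerated), compound 1 reaches only a limit, so no number is known for it (the limit of > 50000 nM in this assay, at which 1 of the 3 values shown sits). Compound 3 has the lowest of the two numbers in this assay, and compound 2 stands a step above it that is beyond the scatter. Compound 4, `CCOC(=O)CNC(=O)NC1=CS(=O)(=O)O[C@@]12[C@@H](CO[Si](C)(C)C(C)(C)C)O[C@@H](n1cc(C)c(=O)n(C)c1=O)[C@@H]2O[Si](C)(C)C(C)(C)C`, has not yet been measured. It differs from compound 3 by ethoxycarbonyl in place of phenyl on a saturated chain carbon bound to an amide-type nitrogen. Nothing measured here shows what such a change does, so the step in this assay from compound 3 to compound 4 is expected to be small, a 1.7-fold higher number from compound 3 to compound 4 (0.23 log units; within the scatter), leaning toward a higher number. Compound 4 is therefore expected to give about 7000 nM, in a range from 2000 nM to 25000 nM.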

Compound 4, half-maximal cytotoxic concentration: 13000 nM
The estimate for compound 4 lay 1.9-fold (0.27 log units) below the measured number; the measured number falls inside the stated range.
By their numbers in this assay, from the lowest: compound 3; then compounds 2 and 4 (each within the scatter of the next). At a limit, above all of these: compound 1.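

In this assay, putting ethoxycarbonyl in place of phenyl on a saturated chain carbon bound to an amide-type nitrogen gives a 3.2-fold higher number from compound 3 to compound 4 (0.50 log units; beyond the scatter). Among these compounds, this is the first single change that can be read at this place, and it shows that the group carried there alters how much compound the cells tolerate. Nothing measured here accounts for the size of this step. The compounds shown leave open what a carboxylic acid, an amine or a longer chain would do at this place, and whether the step would persist without the silyl groups.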